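This account rests on a few compounds, and the source may have more. Where it says the series, first, only, none or still open, it means among the compounds named here.

Compound 1, `N#CC1=C(N)Oc2c(c3nc4ccccc4nc3c3ccccc23)C12C(=O)N(Cc1cnnn1-c1ccc(F)c(Cl)c1)c1ccccc12`, was examined in a functional assay on HepG2 cells (Homo sapiens) for antiproliferative activity, read by MTT assay, with a stated time of 48 h (a higher number here means a weaker inhibitor, a lower number a stronger inhibitor), where compound 1 gives > 50000 nM, a limit of the assay rather than a number. In this assay compound 2, `COc1ccccc1-n1nncc1CN1C(=O)C2(C(C#N)=C(N)Oc3c(N)cc4nc5ccccc5nc4c32)c2ccccc21`, likewise gives > 50000 nM, again only a limit. Compound 2 thus stands at the limit itself, and this holds for everything shown so far (the limit of > 50000 nM in this assay, at which 2 of the 2 values shown sit). Compound 3, `Cc1cc(C)c(-n2nncc2CN2C(=O)C3(C(C#N)=C(N)Oc4c(N)cc5nc6ccccc6nc5c43)c3ccccc32)c(C)c1`, differs from compound 2 by a single change (2,4,6-trimethylphenyl in place of 2-methoxyphenyl on an aromatic nitrogen). For the measured compounds named here, no step between two measured compounds is available, so there is nothing to say how a change on that aromatic nitrogen moves the read-out in this assay; the only guide is that compound 2 sits at the limit. Compound 3 is therefore expected to remain at or near the limit, with an expected step that the limit leaves unreadable from compound 2 to compound 3 in this assay, which is none beyond the scatter. For compound 3 the estimate in this assay is 60000 nM, within a range from 20000 nM to 200000 nM.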

Compound 3, half-maximal inhibitory concentration: 48100 nM
Beside the measured number, compound 3's estimate is 1.2-fold (0.10 log units) above it; low and high end bracket the measured number.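

In this assay, for the compounds shown here, compound 3 gives the only value shown that is a number and not a limit, so 2,4,6-trimethylphenyl on this aromatic nitrogen gives a readable measurement at this position. What can be read is an at least 1.0-fold lower number from compound 2 to compound 3 (0.01 log units; that floor lies within the scatter), and this is only a floor. On these data alone, the true size of the step remains unknown because compound 2 is held at a limit: the limit of > 50000 nM in this assay, at which 2 of the 3 values shown sit.

The compounds shown leave open whether any group on this aromatic nitrogen would move the read-out clearly away from the limit, as the single step compares only 2-methoxyphenyl and 2,4,6-trimethylphenyl. As far as these compounds go, it also remains open what a simple methyl, or a phenyl carrying an amine or a carboxylic acid, would do in this place.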